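This account rests on a few compounds, and the source may have more. Where it says the series, first, only, none or still open, it means among the compounds named here.

Compound 1 `COc1cc(F)c(NC(=O)c2ccnc(O)c2)cc1Nc1nccc(-c2cn(C)c3ccccc23)n1` and compound 2 `COc1cc(F)c(NC(=O)c2ccncc2OC)cc1Nc1nccc(-c2cn(C)c3ccccc23)n1` share one core and differ only by 3-methoxypyridin-4-yl in place of 2-hydroxypyridin-4-yl on a carbonyl carbon. In a functional assay on A549 cells (Homo sapiens) for antiproliferative activity, read by MTT assay, with a stated time of 72 h (on this read-out higher numbers stand for weaker inhibition and lower numbers for stronger inhibition), compound 1 gives 11700 nM, while compound 2 gives 3430 nM, so that a 3.4-fold lower number from compound 1 to compound 2 (0.53 log units; beyond the scatter). Compound 3 `COc1cc(N(C)CCN(C)C)c(NC(=O)c2ccnc(O)c2)cc1Nc1nccc(-c2cn(C)c3ccccc23)n1` is built on a second core, which differs from the core of compound 1 by (2-(dimethylamino)ethyl)(methyl)amino in place of fluoro on an aromatic carbon; in this assay compound 3 gives 11200 nM, and a 1.0-fold lower number from compound 1 to compound 3 (0.02 log units; within the scatter). Among the compounds with values here, compound 4 `COc1cc(N(C)CCN(C)C)c(NC(=O)c2ccncc2OC)cc1Nc1nccc(-c2cn(C)c3ccccc23)n1` has not yet been measured; it differs from compound 3 by 3-methoxypyridin-4-yl in place of 2-hydroxypyridin-4-yl on a carbonyl carbon, which is the same change at the same place as the one seen from compound 1 to compound 2. Because the core swap a 1.0-fold lower number from compound 1 to compound 3 (0.02 log units; within the scatter) left the number essentially unchanged, the step from compound 3 to compound 4 is expected to resemble the earlier one, estimated as a 3.4-fold lower number from compound 3 to compound 4 (0.53 log units; beyond the scatter). Compound 4 is therefore expected near 3300 nM, most likely between 1500 nM and 8000 nM.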

Compound 4, half-maximal inhibitory concentration: 2690 nM
For compound 4 the middle estimate is 1.2-fold (0.09 log units) above the measured one; the range from low to high includes it.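

In this assay, 3-methoxypyridin-4-yl in place of 2-hydroxypyridin-4-yl on the core of compound 3 gives a 4.2-fold lower number from compound 3 to compound 4 (0.62 log units; beyond the scatter), and this change carries over from one core to the other with much the same size: the same change on two cores in this assay, a 3.4-fold lower number (0.53 log units; beyond the scatter) from compound 1 to compound 2 and a 4.2-fold lower number (0.62 log units; beyond the scatter) from compound 3 to compound 4, 1.2-fold (0.09 log units) apart, within the scatter of two such steps. The swap of fluoro for (2-(dimethylamino)ethyl)(methyl)amino gives a 1.3-fold lower number from compound 2 to compound 4 (0.11 log units; within the scatter), and it too reads alike with either pyridinyl group: the same change on two cores in this assay, a 1.0-fold lower number (0.02 log units; within the scatter) from compound 1 to compound 3 and a 1.3-fold lower number (0.11 log units; within the scatter) from compound 2 to compound 4, 1.2-fold (0.09 log units) apart, within the scatter of two such steps. This rests on just two cores in one cell line, so it does not show why the number falls or that the change would carry over to any further core.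

Still open, on these data alone, is how an aminopyridin-4-yl or a chloropyridin-4-yl group would compare on these cores. Also open, as far as these compounds go, is whether a morpholine in place of fluoro would leave the number as little moved.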